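Fluoro-to-methyl swap on a chalcone anilide

The compounds below may be only part of what the source reports. "The series", "measured", "known", "first", "only" and "open" are said of these compounds alone.

Measured so far:
compound 1, `CCCCCCSC(=S)N[C@H]1CCOC1=O`, > 128000 nM (a limit of the assay)
compound 2, `CCCCCCCCCCCCCCSC(=S)N[C@H]1CCOC1=O`, 36600 nM
compound 3, `O=C(CCl)Nc1ccc(C(=O)/C=C/c2ccc(F)cc2)cc1`, 4680 nM

In a functional assay on MGC-803 cells (Homo sapiens) for cytotoxicity, read by MTT assay, with a stated time of 72 h (a higher number here means a weaker inhibitor, a lower number a stronger inhibitor), compound 1 gives > 128000 nM, which is a limit of the assay and not a number; (the limit of > 128000 nM in this assay, at which 1 of the 3 values shown sits). Compound 2 gives 36600 nM in this assay. Among the measured compounds shown here, the one measured step, an at least 3.4-fold lower number from compound 1 to compound 2 (0.54 log units; beyond the scatter), is a change on the thiocarbamate core shared by compound 1 and compound 2. Compound 3 has the lowest of the two numbers given in this assay; compound 2 gives the nearer value, and that gap lies beyond the scatter.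

Compound 4 is `Cc1ccc(/C=C/C(=O)c2ccc(NC(=O)CCl)cc2)cc1`. The change from compound 3: methyl in place of fluoro on an aromatic carbon. For the measured compounds named here, no measured step bears on it; the step from compound 1 to compound 2 concerns a different core and a saturated chain, not an aromatic substituent, so it carries no information on the swap at hand. With nothing in the series to point either way, the expected step from compound 3 to compound 4 in this assay is a 1.1-fold higher number from compound 3 to compound 4 (0.03 log units; within the scatter), that is, none beyond the scatter. Compound 4 is therefore estimated at 5000 nM, with a range from 1800 nM to 14000 nM.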

Compound 4, half-maximal inhibitory concentration: 3600 nM
The estimate for compound 4 lay 1.4-fold (0.14 log units) above the measured number; the range from low to high includes it.
By their numbers in this assay, from the lowest: compounds 4 and 3 (each within the scatter of the next); then compound 2. At a limit, above all of these: compound 1.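

In this assay, among the compounds shown here, the exchange of 4-fluorophenyl for 4-methylphenyl gives the first step on an aromatic carbon (a 1.3-fold lower number from compound 3 to compound 4 (0.11 log units; within the scatter)), and that step stays within the scatter. For the compounds shown here, at this place, para to a large group, fluoro and methyl therefore cannot be told apart in this read-out, whereas the only earlier step concerned a saturated chain on a different core and said nothing about an aromatic substituent. No available evidence bears on this swap, so the result can be recorded only as an observation and carries no explanation.

As far as these compounds go, with only fluoro and methyl at this place, it remains open whether the position responds to substitution at all, since an amine, a carboxylic acid, a methoxy group or a longer chain there could still move the number beyond the scatter. Going by these compounds alone, also open is how much of the value in compound 3 and compound 4 depends on the chloroacetyl group on the anilide nitrogen, as no compound here carries a plain acetyl group or another replacement in its place.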